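This account rests on a few compounds, and the source may have more. Where it says the series, first, only, none or still open, it means among the compounds named here.

Working notes on the series.

Of the compounds shown here, three of the shared core have been measured in a functional assay (muscle tissue) with Cavia porcellus as the target; on this read-out lower numbers stand for an effect already at smaller amounts and higher numbers for an effect only at larger amounts of compound. Compound 1 `COC(=O)C1=C(C)N=C(C)/C(=C(\O)OC)C1c1cccc([N+](C)(C)C)c1` gives 50100 nM. Compound 2 `COC(=O)C1=C(C)N=C(C)/C(=C(\O)OC)C1c1cc(Cl)cc(Cl)c1` gives 93.3 nM. Compound 3 `COC(=O)C1=C(C)N=C(C)/C(=C(\O)OC)C1c1cccc(N(C)C)c1` gives 891 nM.

Compound 3 thus holds the second highest of the three numbers: compound 2 shows a number well below it, compound 1 a number far above it, and both gaps lie beyond the scatter.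

The step in view leads from compound 3 to compound 4 `COC(=O)C1=C(C)N=C(C)/C(=C(\O)OC)C1c1cccc(Br)c1` by the change (bromo in place of dimethylamino on an aromatic carbon).

For the measured compounds named here, only one measured step on the same aromatic carbon bears on this: a 56-fold lower number from compound 1 to compound 3 (1.75 log units; beyond the scatter). It shows that the substituent on this ring position moves this assay by a large amount. Going by the values given here, compound 2 carries halogens on the same ring and gives the lowest number of the three, so a halogen in this place is compatible with a lower number than compound 3, although no single-point step from compound 2 to compound 3 exists in the data.

Among the compounds with values here, on that basis a lower number than compound 3 is expected for compound 4, a step of a 5.9-fold lower number from compound 3 to compound 4 (0.77 log units; beyond the scatter), with wide uncertainty because of the single bearing step a 56-fold lower number from compound 1 to compound 3 (1.75 log units; beyond the scatter). The estimate for compound 4 in this assay is 150 nM, within 40 nM to 600 nM.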

Compound 4, half-maximal effective concentration: 1.29 nM
Compound 4: the middle estimate sits 120-fold (2.07 log units) above what was measured; measured number below the stated range.
By their numbers in this assay, from the lowest: compound 4; then compound 2; then compound 3; then compound 1.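

The bromo group turns this aromatic carbon into the most sensitive point seen so far in this assay: a 690-fold lower number from compound 3 to compound 4 (2.84 log units; beyond the scatter) is larger than the step from the group of 4 heavy atoms to dimethylamino, and the full span at this one carbon reaches a 39000-fold lower number from compound 1 to compound 4 (4.59 log units; beyond the scatter). Halogen on the ring does not by itself set the level, as 3-bromophenyl in place of 3,5-dichlorophenyl still gives a 72-fold lower number from compound 2 to compound 4 (1.86 log units; beyond the scatter), which places compound 4 beyond the scatter from all three earlier compounds and lowest of the four. Nothing at hand gives a reason for the size of these steps.

As far as these compounds go, what stays open is whether the low number belongs to bromine itself or to a single substituent on the aromatic ring, a question that compound 2 cannot settle, as it differs from compound 4 in both the halogen and the substitution pattern. A lone chloro, an iodo, a methyl or a nitrile on the same aromatic carbon would separate these readings and show how far the series follows the bromo group.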